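Working notes: from compound 3 to compound 4

A few compounds are considered here, and "the series" means these few. Any claim that something is new, unique, unknown or untested is made for them only; others in the source may bear on it.

Values in a functional assay on HT-29 cells (Homo sapiens) for inhibition, read by MTT assay, with a stated time of 48 h (on this read-out higher numbers stand for weaker inhibition and lower numbers for stronger inhibition), are as follows
compound 1 `COc1ccc(-n2c(S)nnc2-c2cc(OC)c(OC)c(OC)c2)cc1` gives > 60000 nM
compound 2 `COc1ccc(-n2c(SC)nnc2-c2cc(OC)c(OC)c(OC)c2)cc1` gives > 60000 nM
compound 3 `COc1ccc(-n2c(SCc3ccc(C)cc3)nnc2-c2cc(OC)c(OC)c(OC)c2)cc1` gives > 60000 nM

Each of these values is a limit of the assay and not a number. Compound 3 stands with the others at the limit of > 60000 nM in this assay, at which 3 of the 3 values shown sit, and has no number of its own. Compound 4 `COc1ccc(C(=O)CSc2nnc(-c3cc(OC)c(OC)c(OC)c3)n2-c2ccc(OC)cc2)cc1` carries (4-methoxyphenyl)carbonyl in place of 4-methylphenyl on a saturated chain carbon bound to a sulfur on the same core. Going by the values given here, three measured steps bear on this change: a step that the two limits leave unreadable from compound 1 to compound 2 and a step that the two limits leave unreadable from compound 1 to compound 3 and a step that the two limits leave unreadable from compound 2 to compound 3 and none of them has a readable size. No step beyond the scatter is therefore expected in this assay in either direction. The estimate is a number no higher from compound 3 to compound 4 (the limit leaves the size open) and it remains only an expectation. Compound 4 is expected at 60000 nM with an estimated range from 20000 nM to 120000 nM and a limit of the assay is the likeliest outcome.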

Compound 4, half-maximal inhibitory concentration: > 60000 nM
Compound 4 gave a limit, no number (the forecaster's own chance of this, stated with the estimate: 70%); the middle value sits exactly at the limit.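

No new step between compound 4 and compound 1, compound 2 or compound 3 can be read in this assay: the limit of > 60000 nM in this assay, at which 4 of the 4 values shown sit.

The compounds shown leave open what number any of them would give and how large any of these changes is.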